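A smaller substituent on the aromatic nitrogen

The source may hold more compounds than are shown below. What is called first, only, known or untested is meant among the compounds shown, and "the series" means these compounds.

Measured so far:
compound 1, `N#Cc1c(-c2ccc(Cl)cc2)cc(-c2ccc(Cl)cc2)n([C@@H]2O[C@H](CO)[C@@H](O)[C@H]2O)c1=O`: 6.9 ug/mL
compound 2, `N#Cc1c(-c2ccc(Cl)cc2)cc(-c2ccc(Cl)cc2)n([C@@H]2O[C@H](COC(=O)c3ccccc3)[C@@H](OC(=O)c3ccccc3)[C@H]2OC(=O)c2ccccc2)c1=O`: 8 ug/mL

In a functional assay on HepG2 cells (Homo sapiens) for cytotoxicity, read by sulforhodamine B assay, with a stated time of 48 h (on this read-out lower numbers stand for stronger inhibition and higher numbers for weaker inhibition), compound 1 gives 6.9 ug/mL, the lowest of the two numbers shown. Compound 2 gives 8 ug/mL, which lies within the scatter of the first value. Compound 3, `N#Cc1c(-c2ccc(Cl)cc2)cc(-c2ccc(Cl)cc2)n(CC2CO2)c1=O`, has not yet been measured. It differs from compound 1 in one place: (oxiran-2-yl)methyl in place of 3,4-dihydroxy-5-(hydroxymethyl)oxolan-2-yl on an aromatic nitrogen. Among the measured compounds shown here, no step between measured compounds is available to guide the expectation, so only a small shift is expected, a 1.2-fold lower number from compound 1 to compound 3 (0.06 log units; within the scatter), not clearly beyond the scatter. Compound 3 is therefore estimated at 6 ug/mL, with a range from 2 ug/mL to 18 ug/mL.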

Compound 3, half-maximal inhibitory concentration: 6.2 ug/mL
Compound 3: the middle estimate sits 1.0-fold (0.01 log units) below what was measured, within the range that was stated.
By their numbers in this assay, from the lowest: compounds 3, 1 and 2 (each within the scatter of the next).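

Moving from 3,4-dihydroxy-5-(hydroxymethyl)oxolan-2-yl to (oxiran-2-yl)methyl on the aromatic nitrogen in this assay gives a 1.1-fold lower number from compound 1 to compound 3 (0.05 log units; within the scatter). At this position, then, a much smaller group with no hydrogen-bond donors and no defined stereocentres gives a number within the scatter of compound 1. Nothing measured here explains this result.

On these data alone, it remains open whether the three-membered ring matters at all, and how a plain propyl chain, an amine or a carboxylic acid on this nitrogen would compare with compound 3.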